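Swapping a sulfur-linked group for ethoxy on a triazole core

A few compounds are considered here, and "the series" means these few. Any claim that something is new, unique, unknown or untested is made for them only; others in the source may bear on it.

For the measured compounds named here, compound 2 `c1ccc(CSc2nnc(Cc3ccccc3Oc3ccccc3)[nH]2)cc1` is one of two compounds measured in a functional assay on the whole organism (strain NMRI) with Mus musculus as the target, with a stated time of 60 min, at a dose of 5 mg/kg by the intraperitoneal route; a higher number here means a stronger effect of the compound at the dose given, a lower number a weaker effect. Compound 2 gives 129%, the higher of the two numbers, while compound 1 `CSc1nnc(Cc2ccccc2Oc2ccccc2)[nH]1` gives 120%; the step of a number 9 percentage points higher from compound 1 to compound 2 (within the scatter) lies within the scatter. Compound 3 `CCOc1nnc(Cc2ccccc2Oc2ccccc2)[nH]1` is not yet measured. It differs from compound 2 by ethoxy in place of benzylsulfanyl on an aromatic carbon. Going by the values given here, no measured step covers this exchange; the only known step changed the group at the same place and stayed within the scatter. For compound 3 the expected change is therefore a number 14 percentage points lower from compound 2 to compound 3 (beyond the scatter), none beyond the scatter. Compound 3 is estimated at 115%, between 90% and 140%.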

Compound 3, a percentage reported as activity, at one dose (the size of the read-out at that dose, not a potency): 123%
Compound 3: middle estimate off by 8 percentage points, on the low side; the range from low to high includes it.
By their numbers in this assay, from the lowest: compounds 1, 3 and 2 (each within the scatter of the next).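

In this assay, replacing the sulfur-linked group with ethoxy on this aromatic carbon gives a number 6 percentage points lower from compound 2 to compound 3 (within the scatter) and a number 3 percentage points higher from compound 1 to compound 3 (within the scatter). This position therefore now carries an oxygen link as well as a sulfur link, and ring-free ethoxy as well as ring-bearing benzylsulfanyl, with no step beyond the scatter. Nothing available explains why these three groups give such similar numbers. As far as these compounds go, it remains open whether an amine or a carboxylic acid on this carbon would move the number beyond the scatter.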